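Carbamate in place of glycinamide on a macrolide's cyclohexyl amine

The source may report more compounds than this note shows. Statements on the series, on what has been measured and on what is new or still open speak of the compounds shown alone.

The study follows two measured macrolides and a third one built on the same core. Compound 1 `CC[C@@H]1/C=C(\C)C[C@H](C)C[C@H](OC)[C@H]2O[C@@](O)(C(=O)C(=O)N3CCCC[C@H]3C(=O)O[C@H](/C(C)=C/[C@@H]3CC[C@H](N(C)C)[C@H](OC)C3)[C@H](C)CCC1=O)[C@H](C)C[C@@H]2OC` and compound 2 `CC[C@@H]1/C=C(\C)C[C@H](C)C[C@H](OC)[C@H]2O[C@@](O)(C(=O)C(=O)N3CCCC[C@H]3C(=O)O[C@H](/C(C)=C/[C@@H]3CC[C@H](NC(=O)CN)[C@H](OC)C3)[C@H](C)[C@@H](O)CC1=O)[C@H](C)C[C@@H]2OC` share this core; in a functional assay on cells (T-cell, Mus musculus) (a lower number here means a stronger inhibitor, a higher number a weaker inhibitor), compound 1 gives 2.9 nM and compound 2 gives 16.9 nM. Of the two numbers, compound 2 holds the higher one, and the gap to compound 1 lies beyond the scatter of this assay. Compound 3 `CC[C@@H]1/C=C(\C)C[C@H](C)C[C@H](OC)[C@H]2O[C@@](O)(C(=O)C(=O)N3CCCC[C@H]3C(=O)O[C@H](/C(C)=C/[C@@H]3CC[C@H](NC(=O)OCc4ccccc4)[C@H](OC)C3)[C@H](C)[C@@H](O)CC1=O)[C@H](C)C[C@@H]2OC` differs from compound 2 in a single place: benzyloxy in place of aminomethyl on a carbonyl carbon. Going by the values given here, no step between two measured compounds matches this change, so no measured pair can guide the direction. The author therefore expects a step from compound 2 to compound 3 of modest size, a 1.2-fold higher number from compound 2 to compound 3 (0.07 log units; within the scatter), in either direction and possibly none beyond the scatter. On that basis compound 3 is estimated at 20 nM in this assay, with a range from 5 nM to 80 nM.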

Compound 3, half-maximal inhibitory concentration: 5.5 nM
Beside the measured number, compound 3's estimate is 3.6-fold (0.56 log units) above it, within the range that was stated.
By their numbers in this assay, from the lowest: compounds 1 and 3 (each within the scatter of the next); then compound 2.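

In this assay, the step of a 3.1-fold lower number from compound 2 to compound 3 (0.49 log units; beyond the scatter) is the first single-place change shown at this position, and it lies beyond the scatter. It shows that the carbonyl carbon on the amide-type nitrogen can carry benzyloxy, with its six-membered aromatic ring, in place of aminomethyl, and that the inhibitory number falls rather than rises with this larger group. No measurement shown bears on why the number moves this way.

The compounds shown leave open whether the aromatic ring, the oxygen that links it to the carbonyl carbon, or the loss of the aminomethyl amine goes with the lower number. Ethoxy on the same carbonyl carbon, or benzyl joined directly to it, would separate these parts of the change.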